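The source may report more compounds than this note shows. Statements on the series, on what has been measured and on what is new or still open speak of the compounds shown alone.

The shared core of compound 1 `COc1ncnc2c1c(I)cn2[C@@H]1O[C@H](CO)[C@@H](O)[C@H]1O` carries an iodo group on one aromatic carbon. In a functional assay on HCT-116 cells (Homo sapiens), read by MTT assay, with a stated time of 72 h (a lower number here means a stronger inhibitor, a higher number a weaker inhibitor), compound 1 gives only a limit, > 20000 nM. Compound 2 `C#Cc1cn([C@@H]2O[C@H](CO)[C@@H](O)[C@H]2O)c2ncnc(OC)c12` has ethynyl in place of iodo, and in this assay compound 2 gives 5140 nM, the only number shown in the set. For the measured compounds named here, the one other value recorded sits at the limit of > 20000 nM in this assay, at which 1 of the 2 values shown sits. Going by the values given here, the sole measured step, an at least 3.8-fold lower number from compound 1 to compound 2 (0.59 log units; beyond the scatter), concerns that exchange alone. Compound 3 `C#Cc1cn([C@@H]2O[C@H](CO)[C@@H](O)[C@H]2O)c2ncnc(N(C)C)c12` differs from compound 2 by dimethylamino in place of methoxy on an aromatic carbon. Among the compounds with values here, no measured step touches this position or this kind of exchange, so the ethynyl-for-iodo step gives no guide to the size or direction of the change. Compound 3 is therefore expected to show a 1.0-fold lower number from compound 2 to compound 3 (0.01 log units; within the scatter), a step no larger than the scatter. The estimate for compound 3 is 5000 nM, expected to fall between 1500 nM and 16000 nM.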

Compound 3, half-maximal inhibitory concentration: 290 nM
The estimate for compound 3 lay 17-fold (1.24 log units) above the measured number; measured number below the stated range.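

In this assay, dimethylamino in place of methoxy gives an 18-fold lower number from compound 2 to compound 3 (1.25 log units; beyond the scatter). This shows that the group on this aromatic carbon of the six-membered aromatic ring matters in its own right: with ethynyl held constant, this single exchange moves the number well beyond the scatter, which the ethynyl-for-iodo step could not reveal. Nothing recorded here bears on the cause of this step.

The compounds shown leave open whether a primary amine, methylamino or a cyclic amine such as pyrrolidine or morpholine at this position would give a similar number. They also leave open whether dimethylamino would have the same effect with iodo rather than ethynyl on the shared core.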